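A Second Methyl, Now on the Nitrogen-Bearing Ring

The source may report more compounds than this note shows. Statements on the series, on what has been measured and on what is new or still open speak of the compounds shown alone.

Compound 2 `COc1ccc(C2(O)/C(=C/c3ccc(C)cc3)CCCC2CN(C)c2ccccc2)cc1` gives 17% in a functional assay on the whole organism (strain Wistar) for inhibition, with Rattus norvegicus as the target, read by paw edema, with stated times of 1 h and 3 h, at a dose of 200 mg/kg by the oral route (a higher number here means more inhibition at the dose given (going by the name of the read-out), a lower number less inhibition), the lower of the two numbers seen so far, while compound 1 `COc1ccc(C2(O)/C(=C/c3ccccc3)CCCC2CN(C)c2ccccc2)cc1` gives 38.3%. Compound 3 `COc1ccc(C2(O)/C(=C/c3ccc(C)cc3)CCCC2CN(C)c2cccc(C)c2)cc1` differs from compound 2 by methyl in place of hydrogen on an aromatic carbon, taking methyl(phenyl)amino to methyl(3-methylphenyl)amino. Among the measured compounds shown here, the only comparable step, a number 21.3 percentage points lower from compound 1 to compound 2 (beyond the scatter), placed the same kind of group on a different ring. A similar drop, or none beyond the scatter, is therefore expected, the low starting point leaving little room to fall. The expected step is a number 7 percentage points lower from compound 2 to compound 3 (within the scatter). Compound 3 is expected to give 10%, within 0% to 25%.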

Compound 3, a percentage reported as inhibition, in the whole organism at one dose (the size of the read-out at that dose, not a potency): 29.8%
The estimate for compound 3 lay 19.8 percentage points below the measured number; the whole stated range lies below it.
By their numbers in this assay, from the lowest: compound 2; then compounds 3 and 1 (each within the scatter of the next).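

The same exchange of hydrogen for methyl does not act the same way on every ring: on the ring of the methyl(phenyl)amino group, this assay shows a number 12.8 percentage points higher from compound 2 to compound 3 (beyond the scatter), while on the other ring it gave a number 21.3 percentage points lower from compound 1 to compound 2 (beyond the scatter). Across these three compounds, the direction of the step therefore depends on where the methyl sits. Nothing measured here accounts for this reversal. As far as these compounds go, it remains open whether an ethyl, a chlorine atom or an amine in place of this methyl would move the number the same way.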